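The source may hold more compounds than are shown below. What is called first, only, known or untested is meant among the compounds shown, and "the series" means these compounds.

In a functional assay on NCI-H1975 cells (Homo sapiens) for antiproliferative activity (a higher number here means a weaker inhibitor, a lower number a stronger inhibitor), compound 1 `Cc1c2c(n3c1CCN(C)C[C@@H](C)[C@H](C)Nc1cc-3ccc1C(N)=O)CC(C)(C)CC2=O` gives 27 nM. Two relatives have also been measured: compound 2 `CC(=O)N1CCCc2c(C)c3c(n2-c2ccc(C(N)=O)c(c2)N[C@@H](C)[C@@H]1C)CC(C)(C)CC3=O` gives 20 nM, and compound 3 `Cc1c2c(n3c1CCCN(C(=O)CO)[C@@H](C)[C@H](C)Nc1cc-3ccc1C(N)=O)CC(C)(C)CC2=O` gives 54 nM. The number for compound 1 lies within the usual scatter of both, so it cannot be separated from either one.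

The next compound, compound 4 `Cc1c2c(n3c1CCN(C(=O)C(C)(C)N)C[C@@H](C)[C@H](C)Nc1cc-3ccc1C(N)=O)CC(C)(C)CC2=O`, is made from compound 1 by placing (1-amino-1-methylethyl)carbonyl in place of methyl on an amine nitrogen in a ring. Among the compounds with values here, no measured step shows this exchange directly. Compounds 2 and 3 do carry a carbonyl group on a ring nitrogen, but their core is not identical to that of compound 1, so they offer only indirect guidance.

Within the data shown here, the one measured step is a 2.7-fold higher number from compound 2 to compound 3 (0.43 log units; beyond the scatter), where hydroxy replaces hydrogen on a saturated chain carbon bound to a carbonyl carbon. That step is modest, and it shows that a small addition to such a group can move the number a little. With a carbonyl group on the ring nitrogen, compound 2 still gives 20 nM and compound 3 gives 54 nM, so a large loss in this assay is not expected.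

The expected change is small and slightly upward, with an estimated 1.5-fold higher number from compound 1 to compound 4 (0.17 log units; within the scatter). The estimate for compound 4 is 40 nM, with an expected range from 12 nM to 130 nM.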

Compound 4, half-maximal inhibitory concentration: 21 nM
Beside the measured number, compound 4's estimate is 1.9-fold (0.28 log units) above it; the measured number falls inside the stated range.
By their numbers in this assay, from the lowest: compounds 2, 4, 1 and 3 (each within the scatter of the next, the first and the last beyond it).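

In this assay, placing (1-amino-1-methylethyl)carbonyl in place of methyl on the amine nitrogen in the ring gives a 1.3-fold lower number from compound 1 to compound 4 (0.11 log units; within the scatter), so this exchange leaves no change that can be told from the scatter. Within the data shown here, this is the first direct reading at this position on the core of compound 1, since the carbonyl groups on a ring nitrogen in compounds 2 and 3 sit on a different core; here 6 heavy atoms, with 1 hydrogen-bond donor and 2 hydrogen-bond acceptors, enter where 1 heavy atom leaves, and the number holds. No measurement at hand explains why the number holds.

The compounds shown leave open whether the amino group or the two methyl groups of the entering group play any part in this result, as a single exchange cannot separate the parts of the group. As far as these compounds go, it also remains open how far this tolerance extends, for example to a carboxylic acid or a longer chain on the same nitrogen of the core of compound 1.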